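The source may hold more compounds than are shown below. What is called first, only, known or untested is meant among the compounds shown, and "the series" means these compounds.

Measured so far:
compound 1, `O=C(O)C1(c2nn(Cc3cn4cc(OCC5CC5)c(Cl)cc4n3)c3ccccc3c2=O)CC1` — 16 nM
compound 2, `CC(C)(C(=O)O)c1nn(Cc2cn3cc(OCC4CC4)c(Cl)cc3n2)c2ccccc2c1=O` — 7.7 nM

For the measured compounds named here, in a functional assay on CHO cells for antagonist activity at sphingosine 1-phosphate receptor 2 (Homo sapiens), read by calcium flux (on this read-out lower numbers stand for stronger inhibition and higher numbers for weaker inhibition), compound 2 gives 7.7 nM, the lowest of the two numbers so far; the nearest is compound 1 with 16 nM, and the step of a 2.1-fold lower number from compound 1 to compound 2 (0.32 log units; beyond the scatter) is modest but beyond the scatter. Compound 3, `CCC(C(=O)O)c1nn(Cc2cn3cc(OCC4CC4)c(Cl)cc3n2)c2ccccc2c1=O`, has not yet been measured in this assay. It differs from compound 2 by 1-carboxypropyl in place of 1-carboxy-1-methylethyl on an aromatic carbon. Going by the values given here, only one measured step touches this position, a 2.1-fold lower number from compound 1 to compound 2 (0.32 log units; beyond the scatter), and it compares a ring with an open branched group; nothing measured compares two open groups of the same composition joined differently. That single step was modest, so the expected change from compound 2 to compound 3 is small, with no clear direction, and most likely within the scatter: a 1.6-fold higher number from compound 2 to compound 3 (0.19 log units; within the scatter) is the estimated step. Compound 3 is therefore expected to give about 12 nM in this assay, within a range of 4 nM to 40 nM.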

Compound 3, half-maximal inhibitory concentration: 5.6 nM
Estimate against measurement, compound 3: 2.1-fold (0.33 log units) above; the range from low to high includes it.
By their numbers in this assay, from the lowest: compounds 3 and 2 (each within the scatter of the next); then compound 1.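

In this assay, for the compounds shown here, rearranging the same atoms from 1-carboxy-1-methylethyl to 1-carboxypropyl gives a 1.4-fold lower number from compound 2 to compound 3 (0.14 log units; within the scatter) and so leaves the read-out within the scatter, the first comparison of two open groups at this position. Set against 1-carboxycyclopropyl, the open 1-carboxypropyl gives a 2.9-fold lower number from compound 1 to compound 3 (0.46 log units; beyond the scatter) and thus joins 1-carboxy-1-methylethyl in standing apart from compound 1 by a step beyond the scatter, so the difference no longer rests on a single open group. Nothing available explains why the two open groups read alike or why they differ from the cyclopropyl group.

The compounds shown leave open how a longer chain such as 1-carboxybutyl would read at this position. They also leave open whether the carboxylic acid could give way to an amide or a tetrazole on these open groups.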